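Swapping fluoro for tert-butyl in a cytotoxicity series

A few compounds are considered here, and "the series" means these few. Any claim that something is new, unique, unknown or untested is made for them only; others in the source may bear on it.

For the measured compounds named here, compound 2 `COc1ccc(/C=C2/CN(C)/C(=N/c3ccc(F)cc3)S2)cc1` gives 42800 nM in an ADME assay on TERT-RPE1 cells (Homo sapiens) for cytotoxicity, read by MTT assay, with a stated time of 72 h (a lower number here means a stronger inhibitor, a higher number a weaker inhibitor), the lowest of the two numbers known, with compound 1 `COc1ccc(/C=C2/CN(C)/C(=N/c3ccc(C)cc3)S2)cc1` at 65700 nM as its nearest neighbour; the step of a 1.5-fold lower number from compound 1 to compound 2 (0.19 log units; within the scatter) lies within the scatter. In this assay compound 3 `COc1ccc(/C=C2\S/C(=N\c3ccc(F)cc3)N(C)C2=O)cc1` gives only a limit, > 100000 nM. That value is the limit of > 100000 nM in this assay, at which 1 of the 3 values shown sits, not a number.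

Compound 4 `COc1ccc(/C=C2/CN(C)/C(=N/c3ccc(C(C)(C)C)cc3)S2)cc1` is not yet measured and differs from compound 2 by tert-butyl in place of fluoro on an aromatic carbon. Going by the values given here, the single measured step at this position, a 1.5-fold lower number from compound 1 to compound 2 (0.19 log units; within the scatter), exchanged methyl for fluoro and stayed within the scatter; no measured step involves a tert-butyl group, so the data give no firm direction for a larger group here. He therefore expects the step from compound 2 to compound 4 to be a 1.1-fold lower number from compound 2 to compound 4 (0.03 log units; within the scatter), that is, no change beyond the scatter. For compound 4 he estimates 40000 nM in this assay, with a range from 15000 nM to 110000 nM.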

Compound 4, half-maximal inhibitory concentration: 23500 nM
Compound 4: the middle estimate sits 1.7-fold (0.23 log units) above what was measured, within the range that was stated.
By their numbers in this assay, from the lowest: compounds 4, 2 and 1 (each within the scatter of the next, the first and the last beyond it). At a limit, above all of these: compound 3.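

In this assay, tert-butyl in place of fluoro on an aromatic carbon gives a 1.8-fold lower number from compound 2 to compound 4 (0.26 log units; within the scatter), so this change alone does not separate the two compounds. Tert-butyl in place of methyl gives a 2.8-fold lower number from compound 1 to compound 4 (0.45 log units; beyond the scatter), a modest step and the only one shown at this position that lies beyond the scatter. Nothing measured here accounts for that step.

The compounds shown leave open how an amine, a carboxylic acid or a longer chain would read at this aromatic carbon in this assay. On these data alone, compound 3 gives only a limit, > 100000 nM, which is not a number, and whether tert-butyl in place of fluoro would shift the reading on its core also stays open.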